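A few compounds are considered here, and "the series" means these few. Any claim that something is new, unique, unknown or untested is made for them only; others in the source may bear on it.

Working notes on the series

Compound 3 `CC(=O)N[C@@H](C)C(=O)N(C)/N=N/c1ccc(C)cc1` gives the highest of the three numbers in a physicochemical assay for metabolic stability, read by HPLC, in phosphate buffer, at pH 7.7 (a higher number here means that the compound lasts longer, a lower number that the compound disappears faster), with 46.5 h. Compound 1 `CC(=O)N[C@@H](C)C(=O)N(C)/N=N/c1ccc(Br)cc1` stands nearest with 25.5 h, and the step of a 1.8-fold higher number from compound 1 to compound 3 (0.26 log units; within the scatter) lies within the scatter. Compound 2 `CCOC(=O)c1ccc(/N=N/N(C)C(=O)[C@H](C)NC(C)=O)cc1` stands furthest with 15.7 h, and the step of a 3.0-fold higher number from compound 2 to compound 3 (0.47 log units; beyond the scatter) lies beyond it. The change to compound 4 `CC(=O)N[C@@H](C)C(=O)N(C)/N=N/c1ccc(C(C)=O)cc1` is acetyl in place of methyl on an aromatic carbon. Among the measured compounds shown here, the step that bears most on it is the one from compound 2 to compound 3, where methyl replaced a carbonyl-bearing group at the same place; the present change runs the other way in kind. A modest fall is therefore expected, of about a 2.6-fold lower number from compound 3 to compound 4 (0.41 log units; beyond the scatter). Compound 4 is accordingly estimated at 18 h, with a range of 10 h to 32 h.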

Compound 4, half-life: 13.9 h
Estimate against measurement, compound 4: 1.3-fold (0.11 log units) above; the range from low to high includes it.
By their numbers in this assay, from the lowest: compounds 4, 2, 1 and 3 (each within the scatter of the next, the first and the last beyond it).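

In this assay, acetyl on this aromatic carbon gives a step beyond the scatter (a 3.3-fold lower number from compound 3 to compound 4 (0.52 log units; beyond the scatter)), so methyl now stands apart from two carbonyl-bearing groups, acetyl and ethoxycarbonyl. Methyl in place of ethoxy on the carbonyl carbon (a 1.1-fold lower number from compound 2 to compound 4 (0.05 log units; within the scatter)) and acetyl in place of bromo (a 1.8-fold lower number from compound 1 to compound 4 (0.26 log units; within the scatter)) both stay within the scatter, so acetyl cannot be told apart from either group here. Nothing at hand gives a cause for these steps. As far as these compounds go, whether an amine, a carboxylic acid or a longer alkyl chain at this place would stand with methyl or with the other three groups remains open.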